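A few compounds are considered here, and "the series" means these few. Any claim that something is new, unique, unknown or untested is made for them only; others in the source may bear on it.

Compound 1 `c1ccc2cc(NC3=NCCO3)ccc2c1`: 4500 nM
Compound 2 `c1cc(C2CCCCC2)ccc1NC1=NCCO1`: 17500 nM

In a functional assay on MCF7 cells (Homo sapiens) for inhibition, read by sulforhodamine B assay, with a stated time of 48 h (a higher number here means a weaker inhibitor of growth, a lower number a stronger inhibitor of growth), compound 2 stands highest of the two, at 17500 nM, a gap beyond the scatter from compound 1. Compound 3 `c1ccc(-c2ccc(NC3=NCCO3)cc2)cc1` has phenyl in place of cyclohexyl on an aromatic carbon. No single change between measured compounds shows what such a swap does. With compound 1 at 4500 nM as the only lower reference, a small fall in this assay is expected, just beyond the scatter. The estimated change is a 2.2-fold lower number from compound 2 to compound 3 (0.34 log units; beyond the scatter). For compound 3 the expected value is 8000 nM, with an estimated range of 3000 nM to 22000 nM.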

Compound 3, concentration for 50% growth inhibition: 10600 nM
Compound 3: the middle estimate sits 1.3-fold (0.12 log units) below what was measured; low and high end bracket the measured number.
By their numbers in this assay, from the lowest: compound 1; then compounds 3 and 2 (each within the scatter of the next).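

In this assay, phenyl in place of cyclohexyl on an aromatic carbon gives a 1.7-fold lower number from compound 2 to compound 3 (0.22 log units; within the scatter) and so stays within the scatter. Among these compounds, this is the first single change measured, and at this place the assay does not separate the aromatic ring from the non-aromatic ring of six carbons. Nothing available explains this result. The compounds shown leave open what an amine, a carboxylic acid or a longer chain would do at this place. They also leave open whether this swap would give the same result on another core.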